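The compounds below may be only part of what the source reports. "The series", "measured", "known", "first", "only" and "open" are said of these compounds alone.

Measured so far, in a physicochemical assay for acid dissociation:

compound 1 `Brc1ccc(Br)c(N(CC2CC2)C2=NCCN2)c1` — 11
compound 2 `Brc1ccc(N(CC2CC2)C2=NCCN2)c(Br)c1` — 11.2
compound 3 `C=CCN(C1=NCCN1)c1c(Br)cccc1Br` — 10.7

All three share one core and differ in the placing of the two bromines and in the group on the nitrogen. In this assay compound 3 gives 10.7; compound 1 gives 11, and the gap between these two lies within the usual scatter, so no order can be read between them. Compound 2 gives 11.2, and the gap from compound 3 to compound 2 lies beyond the scatter. Among the compounds with values here, no pair among the three differs in one place only, so no single step is isolated here.

Compound 4 `Brc1cccc(Br)c1N(Cc1ccccc1)C1=NCCN1` is the next case and has not been measured in this assay. It keeps the bromine pattern of compound 3 and differs from it in one place: phenyl in place of vinyl on a saturated chain carbon bound to a nitrogen on an aromatic ring.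

Within the data shown here, no measured step of this kind is available. The expectation is a step from compound 3 to compound 4 of a number 0.10 log units lower from compound 3 to compound 4 (within the scatter), that is none beyond the scatter, with a slight lean downward if anything. For compound 4 the estimate in this assay is 10.6, with a range from 10.2 to 11.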

Compound 4, acid dissociation constant: 10.4
The estimate for compound 4 lay 0.20 log units above the measured number, within the range that was stated.
By their numbers in this assay, from the lowest: compounds 4, 3, 1 and 2 (each within the scatter of the next, the first and the last beyond it).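

In this assay the series now has its first step confined to one place: a number 0.30 log units lower from compound 3 to compound 4 (within the scatter) for phenyl in place of vinyl on a saturated chain carbon bound to a nitrogen on an aromatic ring. Cut one bond further out, the same difference reads allyl to benzyl, and it brings in a six-membered aromatic ring with 6 heavy atoms where vinyl had 2, yet no order can be read between the two compounds at this position. Nothing measured here bears on the origin of this step.

Open, going by these compounds, is whether a carboxylic acid, an amine or a longer chain at the same place would also stay within the scatter of compound 3. Also open, on these data alone, is whether phenyl in place of vinyl reads the same with the bromine pattern of compound 1 or that of compound 2.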